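A few compounds are considered here, and "the series" means these few. Any claim that something is new, unique, unknown or untested is made for them only; others in the source may bear on it.

Compound 1, `CC(C)c1c(C(=O)N(C)Cc2ccccc2)nn(-c2ccc(F)cc2)c1CC[C@@H](O)C[C@@H](O)CC(=O)O`: 2870 nM
Compound 2, `CC(C)c1c(C(=O)N(C)Cc2cccc(F)c2)nn(-c2ccc(F)cc2)c1CC[C@@H](O)C[C@@H](O)CC(=O)O`: 1900 nM
Compound 3, `CC(C)c1c(C(=O)N(C)Cc2ccc(F)c(F)c2)nn(-c2ccc(F)cc2)c1OC[C@@H](O)C[C@@H](O)CC(=O)O`: 4570 nM

Of the compounds shown here, three have been measured in a functional assay on L6 cells (Rattus norvegicus) for inhibition; on this read-out lower numbers stand for stronger inhibition and higher numbers for weaker inhibition. Compound 2 gives 1900 nM, and the step of a 1.5-fold higher number from compound 2 to compound 1 (0.18 log units; within the scatter) comes with hydrogen in place of fluoro on an aromatic carbon. Compound 3 gives 4570 nM; how its core differs from the core of compound 2 is not broken down here, so only the two values themselves can be set against each other.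

Compound 4, `CC(C)c1c(C(=O)N(C)Cc2ccc(F)cc2)nn(-c2ccc(F)cc2)c1OC[C@@H](O)C[C@@H](O)CC(=O)O`, has not yet been measured. It differs from compound 3 by hydrogen in place of fluoro on an aromatic carbon. Among the compounds with values here, this is the same kind of change as the one from compound 2 to compound 1, but not the same: in compound 3 the leaving fluoro sits ortho to a fluoro group and meta to a large group, whereas in compound 2 it sits only meta to a large group, and the two cores also differ. Because a 1.5-fold higher number from compound 2 to compound 1 (0.18 log units; within the scatter) stayed within the scatter, a small step is expected here too, a 1.2-fold higher number from compound 3 to compound 4 (0.08 log units; within the scatter), and compound 4 is estimated at 5500 nM, within 2500 nM to 12000 nM.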

Compound 4, half-maximal inhibitory concentration: 2800 nM
Estimate against measurement, compound 4: 2.0-fold (0.29 log units) above; measured number inside the range.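

In this assay, hydrogen in place of fluoro on an aromatic carbon gives a 1.6-fold lower number from compound 3 to compound 4 (0.21 log units; within the scatter), a small step of the same kind as the one seen on the other core. Both steps lie within the scatter, and so does the gap between them, so the two cores give no sign that they handle this change differently: the same change on two cores in this assay, a 1.5-fold higher number (0.18 log units; within the scatter) from compound 2 to compound 1 and a 1.6-fold lower number (0.21 log units; within the scatter) from compound 3 to compound 4, 2.5-fold (0.39 log units) apart, within the scatter of two such steps. Within the data shown here, this does not show that the change carries over with a fixed size or direction, as it rests on only two pairs, and the fluoro that leaves compound 3 sits ortho to a fluoro group, which is not so for the one that leaves compound 2.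

The compounds shown leave open how the two cores compare when they carry an identical amide side chain. They also leave open whether a chloro or methoxy group on the same aromatic ring would behave as fluoro does here.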